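Working notes: cell tolerance from compound 2 to compound 3

The compounds below may be only part of what the source reports. "The series", "measured", "known", "first", "only" and "open" are said of these compounds alone.

Values so far in an ADME assay on Vero cells (Chlorocebus sabaeus) for cytotoxicity, read by MTT assay, with a stated time of 72 h (a higher number here means that more compound is tolerated, a lower number that less compound is tolerated), for two compounds
- compound 1 `CCO/N=C(\C)CN1CCN(c2c(F)cc3c(=O)c(C(=O)O)cn(C4CC4)c3c2OC)CC1C` gives 31.3 ug/mL
- compound 2 `COc1c(N2CCN(C/C(C)=N/O)C(C)C2)c(F)cc2c(=O)c(C(=O)O)cn(C3CC3)c12` gives 177 ug/mL

Compound 2 holds the higher number of the two in this assay and compound 1 lies below it, beyond the scatter. The move to compound 3 `CCO/N=C(\C)CCN1CCN(c2c(F)cc3c(=O)c(C(=O)O)cn(C4CC4)c3c2OC)CC1C` is a group of 7 heavy atoms (5 carbon, 1 nitrogen, 1 oxygen; no ring) in place of a group of 4 heavy atoms (2 carbon, 1 nitrogen, 1 oxygen; no ring), on a saturated chain carbon bound to an amine nitrogen in a ring and leaves ethyl on the oxygen where compound 2 has hydrogen. For the measured compounds named here, one measured step bears on this, namely a 5.7-fold higher number from compound 1 to compound 2 (0.75 log units; beyond the scatter) with hydrogen in place of ethyl on an oxygen. Read in reverse, that modest step points to a lower number. Going by the values given here, the rest of the change has no measured step of its own. The expected change is a 5.5-fold lower number from compound 2 to compound 3 (0.74 log units; beyond the scatter) as an estimate of similar size. For compound 3 the expected value is 32 ug/mL with an estimated span from 12 ug/mL to 85 ug/mL in this assay at this stage.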

Compound 3, half-maximal cytotoxic concentration: 88.4 ug/mL
Compound 3: middle estimate off by 2.8-fold (0.44 log units), on the low side; the measured number lies above the stated range.
By their numbers in this assay, from the lowest: compound 1; then compounds 3 and 2 (each within the scatter of the next).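

In this assay, ethyl on the oxygen does not settle the number by itself: compounds 1 and 3 both carry it, and the group of 7 heavy atoms, on a saturated chain carbon bound to an amine nitrogen in a ring, gives a 2.8-fold higher number from compound 1 to compound 3 (0.45 log units; beyond the scatter). The same place also takes the group of 7 heavy atoms, with 0 hydrogen-bond donors, in place of the group of 4 heavy atoms, with 1 hydrogen-bond donor, at a 2.0-fold lower number from compound 2 to compound 3 (0.30 log units; within the scatter), so these two compounds are not separated. No measurement at hand accounts for either step.

Hydrogen on the oxygen of the group in compound 3 remains open, as the ethyl and the chain length are changed together from compound 2. On these data alone, a longer chain, or an amine in place of the oxygen-bearing end of the group, also remains open at this place.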